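The source may hold more compounds than are shown below. What is called first, only, known or untested is meant among the compounds shown, and "the series" means these compounds.

For the measured compounds named here, compound 2 `CN1CCN(CCCOc2cccc3nc(Nc4ccc(F)c(F)c4)ccc23)CC1` gives 5130 nM in a functional assay on cells (Panel ovarian (Carcinoma cell lines), Homo sapiens) for inhibition, read by sulforhodamine B assay, with a stated time of 48 h (on this read-out higher numbers stand for weaker inhibition of growth and lower numbers for stronger inhibition of growth), the higher of the two numbers measured so far; compound 1 `CN1CCN(CCCOc2cccc3nc(Nc4ccc(Cl)c(C(F)(F)F)c4)ccc23)CC1` gives 1980 nM in this assay. Going by the values given here, the one measured step, a 2.6-fold higher number from compound 1 to compound 2 (0.41 log units; beyond the scatter), shows that changing the halogen pattern on this ring shifts the number by a modest amount. Compound 3 `CN1CCN(CCCOc2cccc3nc(Nc4cccc(Cl)c4)ccc23)CC1` differs from compound 2 by 3-chlorophenyl in place of 3,4-difluorophenyl on a nitrogen on an aromatic ring. Since compound 1, with its chlorine on that ring, sits lower at 1980 nM, a modest move in that direction is expected, giving a 1.6-fold lower number from compound 2 to compound 3 (0.20 log units; within the scatter). Compound 3 is therefore estimated at 3200 nM, within 1300 nM to 8000 nM.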

Compound 3, concentration for 50% growth inhibition: 2010 nM
The estimate for compound 3 lay 1.6-fold (0.20 log units) above the measured number; the measured number falls inside the stated range.
By their numbers in this assay, from the lowest: compounds 1 and 3 (each within the scatter of the next); then compound 2.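

In this assay, replacing 3,4-difluorophenyl with 3-chlorophenyl on this nitrogen gives a 2.6-fold lower number from compound 2 to compound 3 (0.41 log units; beyond the scatter), while replacing 4-chloro-3-(trifluoromethyl)phenyl with 3-chlorophenyl gives a 1.0-fold higher number from compound 1 to compound 3 (0.01 log units; within the scatter). Among these three compounds, the two rings carrying chlorine therefore sit together, and the difluorinated ring of compound 2 stands apart. No measurement here explains this difference.
Still open is whether the chlorine itself matters, since plain phenyl is not among the compounds shown. A 3-bromophenyl or 3-methoxyphenyl group could show how far other groups on this ring hold the number.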